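A few compounds are considered here, and "the series" means these few. Any claim that something is new, unique, unknown or untested is made for them only; others in the source may bear on it.

Within the data shown here, in a functional assay on MCF7 cells (Homo sapiens) for inhibition (a higher number here means a weaker inhibitor, a lower number a stronger inhibitor), compound 3 `CCC(C)C(NC(=O)n1nnc2ccccc21)C(=O)NCc1ccccc1` gives 69200 nM, the only actual number among the three values at hand. Compound 1 `CCC(C)C(NC(=O)n1nnc2ccccc21)C(=O)NC(c1ccccc1)c1ccccc1` reaches only a limit of the assay, > 100000 nM. Compound 2 `CCC(C)C(NC(=O)NO)C(=O)NCc1ccccc1` likewise gives only a limit, > 100000 nM. The steps of an at least 1.4-fold lower number from compound 1 to compound 3 (0.15 log units; that floor lies within the scatter) and an at least 1.4-fold lower number from compound 2 to compound 3 (0.15 log units; that floor lies within the scatter) thus rest on floors that lie within the scatter, as the limit of > 100000 nM in this assay, at which 2 of the 3 values shown sit, shows. Compound 4 `CCC(C)C(NC(=O)n1nnc2ccccc21)C(=O)NC1CCCC1` carries cyclopentyl in place of benzyl on an amide-type nitrogen. Among the measured compounds shown here, only the step from the diphenylmethyl compound touches the same amide-type nitrogen, and it showed nothing beyond the scatter, so the expected step of a 1.2-fold higher number from compound 3 to compound 4 (0.06 log units; within the scatter) is taken to stay within the scatter, with a real chance of another limit. Compound 4 is estimated at 80000 nM, between 30000 nM and 250000 nM.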

Compound 4, half-maximal inhibitory concentration: 63700 nM
Estimate against measurement, compound 4: 1.3-fold (0.10 log units) above, and the stated range covers the measured number.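

Among these compounds, for the first time, the substituent on the amide-type nitrogen can be compared between two actual numbers in this assay, with a 1.1-fold lower number from compound 3 to compound 4 (0.04 log units; within the scatter). The step from compound 1 rested only on a limit, whereas this one shows directly that cyclopentyl in place of benzyl stays within the scatter. At this position, in this pair, a five-membered non-aromatic ring of carbon only thus serves as well as benzyl.

As far as these compounds go, what an amine or a carboxylic acid on this nitrogen would give remains open. So does whether any group here moves the number beyond the scatter, since the other comparisons end at a limit: the limit of > 100000 nM in this assay, at which 2 of the 4 values shown sit.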